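From Bromo to Fluoro: One Substituent Swapped

The source may hold more compounds than are shown below. What is called first, only, known or untested is meant among the compounds shown, and "the series" means these compounds.

Measured compounds:
compound 1, `COc1cc(OC)c(OC)cc1/C=C/COC(=O)/C=C/c1ccc(Br)cc1`, activity 75%
compound 2, `COc1cc(OC)c(OC)cc1/C=C/COC(=O)/C=C/c1cc(OC)c(OC)c(OC)c1`, activity 75%

Of the compounds shown here, two have been measured in a functional assay on the whole organism (strain Kunming) with Mus musculus as the target, with a stated time of 0.5 h, at a dose of 300 mg/kg by the intraperitoneal route; a higher number here means a weaker effect of the compound at the dose given, a lower number a stronger effect. Compound 1 gives 75%, and compound 2 gives 75%. At the digits shown the two are level, and their gap lies within the scatter of repeated measurements, so nothing can be said about an order between them. Among the compounds with values here, compound 1 thus stands level with its only measured neighbour, compound 2, which shares the same core.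

Compound 3, `COc1cc(OC)c(OC)cc1/C=C/COC(=O)/C=C/c1ccc(F)cc1`, has not yet been measured in this assay. It differs from compound 1 in one place: fluoro in place of bromo on an aromatic carbon. Within the data shown here, no step between two measured compounds shows this particular change, so its effect cannot be read off directly. Among the measured compounds shown here, the one comparison at hand, compound 1 against compound 2, shows that a quite different set of substituents on that aromatic ring leaves the read-out unchanged within the scatter.

On that basis the step of no change at the digits printed from compound 1 to compound 3 (within the scatter) is expected to be none beyond the scatter. For compound 3 the activity in this assay is estimated at 75%, with a range from 60% to 90%.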

Compound 3, a percentage reported as activity, at one dose (the size of the read-out at that dose, not a potency): 75%
Beside the measured number, compound 3's estimate shows no gap at the digits printed, and the stated range covers the measured number.
By their numbers in this assay, from the lowest: compounds 1, 2 and 3 (each within the scatter of the next).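

Measured in this assay, fluoro in place of bromo on an aromatic carbon, para to a large group, gives no change at the digits printed from compound 1 to compound 3 (within the scatter). This is a direct reading of a single change at this position, which the earlier pair could not offer, since compound 1 and compound 2 differ in more than one place. At the dose tested, the bromo of compound 1 can thus be exchanged for fluoro without the read-out moving beyond the scatter, although nothing measured here bears on why that should be so.

Because the read-out is a percentage at a single dose, the compounds shown leave open whether a difference in potency lies behind these level numbers. They also leave open how the read-out would respond to a different kind of group at this position, such as an amine, a carboxylic acid or a longer chain, and whether an amide in place of the ester of the shared core would change it.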